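A few compounds are considered here, and "the series" means these few. Any claim that something is new, unique, unknown or untested is made for them only; others in the source may bear on it.

Values in a functional assay on cells (Homo sapiens) for cytotoxicity, read by MTT assay, with a stated time of 24 h (a lower number here means a stronger inhibitor, a higher number a weaker inhibitor), for the series so far
- compound 1 `CCCCCCCCCCCCCCNC(=O)[C@H](CO)/N=C/c1cccc(C)c1` gives 82900 nM
- compound 2 `CCCCCCCCCCCCCCNC(=O)[C@H](CO)/N=C/c1ccc(OC)cc1` gives 28100 nM
- compound 3 `CCCCCCCCCCCCCCNC(=O)[C@H](CO)/N=C/c1cccc([N+](=O)[O-])c1` gives 104000 nM

The weak end of this small set is shared (a 1.3-fold higher number from compound 1 to compound 3 (0.10 log units; within the scatter)), and the remaining value lies clearly apart (a 3.7-fold higher number from compound 2 to compound 3 (0.57 log units; beyond the scatter)). The next change leads to compound 4 `CCCCCCCCCCCCCCNC(=O)[C@H](CO)/N=C/c1ccccc1` and is hydrogen in place of nitro on an aromatic carbon, meta to a large group (hydrogen in place of nitro on an aromatic carbon). Among the measured compounds shown here, no measured compound lacks a ring substituent, so this removal has no direct precedent. The closest evidence is the swap between methyl and nitro (a 1.3-fold higher number from compound 1 to compound 3 (0.10 log units; within the scatter)). The 4-methoxyphenyl change (a 3.0-fold lower number from compound 1 to compound 2 (0.47 log units; beyond the scatter)) shows that this part of the structure can shift the number modestly. No step beyond the scatter is therefore expected, and the estimated step is small and towards a lower number (a 1.4-fold lower number from compound 3 to compound 4 (0.16 log units; within the scatter)). In this assay the estimate for compound 4 is 72000 nM (expected range 30000 nM to 150000 nM).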

Compound 4, half-maximal inhibitory concentration: 7670 nM
Compound 4: the middle estimate sits 9.4-fold (0.97 log units) above what was measured; measured number outside the range, below it.
By their numbers in this assay, from the lowest: compound 4; then compound 2; then compounds 1 and 3 (each within the scatter of the next).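

In this assay, hydrogen on the ring gives a lower number than each of the substituted compounds (a 14-fold lower number from compound 3 to compound 4 (1.13 log units; beyond the scatter); an 11-fold lower number from compound 1 to compound 4 (1.03 log units; beyond the scatter); a 3.7-fold lower number from compound 2 to compound 4 (0.56 log units; beyond the scatter)). The earlier compounds shown here showed only that nitro and methyl do not separate (a 1.3-fold higher number from compound 1 to compound 3 (0.10 log units; within the scatter)); compound 4 shows that removing the group altogether counts for far more here than exchanging those two, and that 4-methoxyphenyl, the lowest of the substituted compounds, still stands clearly above phenyl. Nothing available gives a reason for this drop.

On these data alone, whether the low number is particular to hydrogen, or would persist with a small group such as fluorine or a hydroxyl on the ring, stays open. Also open, as far as these compounds go, is whether the same group gives the same number at a different ring position, and whether the ring effect holds with a shorter chain on the shared core.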